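Dropping the Fluoro Group: From Compound 3 to Compound 4

A few compounds are considered here, and "the series" means these few. Any claim that something is new, unique, unknown or untested is made for them only; others in the source may bear on it.

Compound 3 (`N/C(=N\NC(=S)N1CCOCC1)c1ccc(F)cn1`) was tested in a functional assay on HeLa cells (Homo sapiens) for cytotoxicity, read by MTT assay, with a stated time of 72 h (a lower number here means a stronger inhibitor, a higher number a weaker inhibitor), where compound 3 gives 1700 nM. This is the lowest of the three numbers recorded so far. Nearest to it stands compound 2 (`Cc1ccnc(/C(N)=N/NC(=S)N2CCCCCC2)c1`), which in this assay gives 7000 nM, a gap that lies beyond the scatter. Furthest stands compound 1 (`N/C(=N\NC(=S)N1CCSCC1)c1ccccn1`), which in this assay gives 7800 nM, again beyond the scatter. Neither compound 1 nor compound 2 differs from compound 3 in one place only, so these gaps tell only what the values themselves show.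

Compound 4 (`N/C(=N\NC(=S)N1CCOCC1)c1ccccn1`) has not yet been measured. Compared with compound 3 it shows (hydrogen in place of fluoro on an aromatic carbon). For the measured compounds named here, no step between measured compounds that differ in a single place is available, so there is no direct precedent for this change. The two measured compounds lacking the fluoro group, compound 1 and compound 2, both give higher numbers than compound 3, but they differ from it in other places too. The step of a 2.4-fold higher number from compound 3 to compound 4 (0.37 log units; beyond the scatter) is expected to be modest, toward a higher number, and may fall within the scatter. Compound 4 is estimated at 4000 nM, within a range from 1500 nM to 10000 nM.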

Compound 4, half-maximal inhibitory concentration: 7300 nM
Compound 4: the middle estimate sits 1.8-fold (0.26 log units) below what was measured; the measured number falls inside the stated range.
By their numbers in this assay, from the lowest: compound 3; then compounds 2, 4 and 1 (each within the scatter of the next).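

In this assay, for the compounds shown here, the step of a 4.3-fold higher number from compound 3 to compound 4 (0.63 log units; beyond the scatter) gives the first single-place reading at this aromatic carbon, two atoms from the ring nitrogen and para to a large group: with the morpholin-4-yl group held constant, the fluoro group is what separates the lowest number in the set from a value in the same range as the others. The second step, a 1.1-fold lower number from compound 1 to compound 4 (0.03 log units; within the scatter), shows that among compounds lacking the fluoro group, morpholin-4-yl in place of thiomorpholin-4-yl on the thiocarbonyl carbon does not separate the two compounds, so this exchange stays within the scatter where the fluoro change does not. No measured information is available to explain either step.

The compounds shown leave open whether the lower number is particular to fluoro or would also appear with another group at this carbon, such as chloro, methoxy or an amine. They also leave open whether fluoro would give a step of similar size alongside thiomorpholin-4-yl or another ring on the thiocarbonyl carbon.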